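Adding a chloro group to compound 1

A few compounds are considered here, and "the series" means these few. Any claim that something is new, unique, unknown or untested is made for them only; others in the source may bear on it.

In a functional assay on MDA-MB-468 cells (Homo sapiens) for antiproliferative activity (a lower number here means a stronger inhibitor of growth, a higher number a weaker inhibitor of growth), compound 1 (`COc1ccc(-c2nc3ccccc3s2)cc1OC`) gives 530 nM as the concentration for half-maximal growth inhibition. Among the measured compounds shown here, only one other compound has a number so far: compound 2 (`COc1ccc(-c2nc3cc(F)ccc3s2)cc1I`) gives 360 nM in the same test. These two values lie within the usual scatter of repeated measurements, so compound 1 cannot be ranked against compound 2 and the pair stands level.

Compound 3 (`COc1ccc(-c2nc3cc(Cl)ccc3s2)cc1OC`) has not yet been measured. It is compound 1 with a single structural change: chloro in place of hydrogen on an aromatic carbon. For the measured compounds named here, no measured pair of compounds differs in just one place, so the data offer no direct guide to the effect of this change, and any forecast is a judgement. A moderate move to a lower number in this assay is expected, which would mean stronger growth inhibition, although a result within the scatter remains possible. The estimated move is a 4.4-fold lower number from compound 1 to compound 3 (0.65 log units; beyond the scatter) and it is uncertain. Compound 3 is expected at about 120 nM with an estimated range of 10 nM to 700 nM in this test.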

Compound 3, concentration for 50% growth inhibition: 1000 nM
For compound 3 the middle estimate is 8.3-fold (0.92 log units) below the measured one, and the stated range ends below it.
By their numbers in this assay, from the lowest: compounds 2, 1 and 3 (each within the scatter of the next, the first and the last beyond it).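

With compound 3, the data gain their first pair of compounds that differ in only one place, and it gives a direct reading of this position on the six-membered aromatic ring of carbon only, part of the fused system. In this assay, chloro in place of hydrogen on this aromatic carbon gives a 1.9-fold higher number from compound 1 to compound 3 (0.28 log units; within the scatter) and so stays within the usual scatter of repeated measurements, which means that compound 1 and compound 3 stand level and a chloro group at this position brings no measurable gain in growth inhibition. The data on hand offer no measurement that could explain this result.

One swap at one position cannot show whether this position matters more generally, and a group of another kind there, such as an amine or a carboxylic acid, could give a quite different number. As far as these compounds go, the effect of the methoxy groups on the other ring is also open, and compound 2 cannot settle it, since it differs from both compound 1 and compound 3 in more than one place.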